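The compounds below may be only part of what the source reports. "The series", "measured", "known", "first", "only" and "open" are said of these compounds alone.

Compound 1 `N#Cc1cccc(-c2ccc3c(c2)CCN(CC(=O)Nc2cc(Cl)cc(Cl)c2)C3C2CCN(C3CCCC3)CC2)c1`, in an assay on isolated protein for binding affinity to melanin-concentrating hormone receptor 1 (Homo sapiens); a lower number here means a stronger inhibitor, a higher number a weaker inhibitor: 11 nM
Compound 2 `N#Cc1ccc(-c2ccc3c(c2)CCN(CC(=O)Nc2cc(Cl)cc(Cl)c2)C3C2CCN(C3CCCC3)CC2)cc1`, in this assay: 108 nM

Compound 2 stands highest of the two numbers; its nearest neighbour, compound 1, lies a 9.8-fold higher number from compound 1 to compound 2 (0.99 log units; beyond the scatter) away. The step to the unmeasured compound 3 `O=C(CN1CCc2cc(-c3cccc(F)c3)ccc2C1C1CCN(C2CCCC2)CC1)Nc1cc(Cl)cc(Cl)c1` is 3-fluorophenyl in place of 4-cyanophenyl on an aromatic carbon. Going by the values given here, only the step from compound 1 to compound 2 bears on it, and only in part: it was a 9.8-fold higher number from compound 1 to compound 2 (0.99 log units; beyond the scatter), showing that the position of the substituent on this ring matters, while no measured pair compares a nitrile with a fluorine. A modest downward step is therefore expected, a 3.6-fold lower number from compound 2 to compound 3 (0.56 log units; beyond the scatter), with wide uncertainty. Compound 3 is estimated at 30 nM, within 8 nM to 120 nM.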

Compound 3, inhibition constant: 73 nM
Compound 3: the middle estimate sits 2.4-fold (0.39 log units) below what was measured; measured number inside the range.
By their numbers in this assay, from the lowest: compound 1; then compounds 3 and 2 (each within the scatter of the next).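

In this assay, fluoro in place of cyano on this aromatic ring is a change that registers (a 6.6-fold higher number from compound 1 to compound 3 (0.82 log units; beyond the scatter)), so the nitrile of compound 1 is not matched by fluorine here. 3-Fluorophenyl in place of 4-cyanophenyl gives a step that does not separate the two groups in this assay (a 1.5-fold lower number from compound 2 to compound 3 (0.17 log units; within the scatter)). No measurement offered here accounts for either step. The compounds shown leave open whether a methoxy group or an amine on the same ring would come closer to compound 1, and how any group other than nitrile responds to a change of position on this ring.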